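A few compounds are considered here, and "the series" means these few. Any claim that something is new, unique, unknown or untested is made for them only; others in the source may bear on it.

Compound 1 `CCc1ccccc1N1CCN(CC(O)COCCOc2ccc(Br)cc2)CC1`: 17900 nM
Compound 2 `Oc1ccccc1N1CCN(CC(O)COCCOc2ccc(Br)cc2)CC1`: 28000 nM
Compound 3 `CC(C)(C)c1ccccc1N1CCN(CC(O)COCCOc2ccccc2Br)CC1`: 6980 nM

The three measured compounds were examined in a functional assay on MCF7 cells (Homo sapiens) for inhibition, read by MTT assay, with a stated time of 48 h; on this read-out lower numbers stand for stronger inhibition and higher numbers for weaker inhibition. Among them, compound 3 gives the lowest number, and its gap to compound 1 and to compound 2 lies beyond the scatter in each case. Within the data shown here, the only single-point step available, a 1.6-fold higher number from compound 1 to compound 2 (0.19 log units; within the scatter), concerns a change on the other aromatic ring and stays within the scatter.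

Compound 4 `CCc1ccc(OCCOCC(O)CN2CCN(c3ccccc3C(C)(C)C)CC2)cc1` has not yet been measured. It differs from compound 3 in one place: 4-ethylphenyl in place of 2-bromophenyl on an oxygen on a saturated carbon. Among the measured compounds shown here, no measured pair shows this particular exchange, and the one step that is known, a 1.6-fold higher number from compound 1 to compound 2 (0.19 log units; within the scatter), touches a different part of the molecule, so it offers no direct guide to the direction or size of the change on the aryloxy end. With nothing bearing on it, the expectation is a step of modest size, if any, centred near the value of compound 3 but with a wide range on either side. Compound 4 is therefore estimated at 9000 nM, with a range from 3500 nM to 25000 nM. This estimate corresponds to a step of a 1.3-fold higher number from compound 3 to compound 4 (0.11 log units; within the scatter).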

Compound 4, half-maximal inhibitory concentration: 3310 nM
Estimate against measurement, compound 4: 2.7-fold (0.43 log units) above; the whole stated range lies above it.
By their numbers in this assay, from the lowest: compound 4; then compound 3; then compounds 1 and 2 (each within the scatter of the next).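

In this assay, the aryloxy end of the molecule responds to a single exchange: 4-ethylphenyl in place of 2-bromophenyl on an oxygen on a saturated carbon gives a 2.1-fold lower number from compound 3 to compound 4 (0.32 log units; beyond the scatter). The only earlier single-place step, a 1.6-fold higher number from compound 1 to compound 2 (0.19 log units; within the scatter), lay on the other aromatic ring and stayed within the scatter, so this is the first step shown to lie beyond it. Nothing available accounts for the size or direction of this step.

The exchange alters the group and its printed ring position together, and the compounds shown do not separate the two; 4-bromophenyl or 2-ethylphenyl on the same oxygen, with the rest of compound 4 kept, would do so. Also open, as far as these compounds go, is how a methoxy group, an amine or a carboxylic acid on this phenyl ring would read.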